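Dichlorophenyl in place of pyridinyl on a tetrazole acetamide

The source may hold more compounds than are shown below. What is called first, only, known or untested is meant among the compounds shown, and "the series" means these compounds.

Among the measured compounds shown here, compound 2 `Cc1cc(NC(=O)Cn2nnc(-c3ccccn3)n2)n(C2CCCCC2)n1` is measured in an assay on HEK293 cells for activation of Kir3.1/Kir3.2 (Homo sapiens), read by thallium flux (on this read-out higher numbers stand for an effect only at larger amounts of compound and lower numbers for an effect already at smaller amounts), where it gives 14600 nM, the highest of the two numbers so far. For the measured compounds named here, its nearest neighbour is compound 1 `Cc1cc(NC(=O)Cn2nnc(-c3ccccc3)n2)n(C2CCCCC2)n1`, which in this assay gives 96 nM; the only step recorded, a 150-fold higher number from compound 1 to compound 2 (2.18 log units; beyond the scatter), is pyridin-2-yl in place of phenyl on an aromatic carbon. Compound 3 `Cc1cc(NC(=O)Cn2nnc(-c3ccc(Cl)c(Cl)c3)n2)n(C2CCCCC2)n1` has not yet been measured. It differs from compound 2 by 3,4-dichlorophenyl in place of pyridin-2-yl on an aromatic carbon. Going by the values given here, no measured step carries exactly this change, but the one recorded step bears on it. Among the compounds with values here, the ring of carbon only that enters in compound 3 is the kind of ring that compound 1 carries, and compound 1 gives 96 nM. In this assay a large step downward is therefore expected from compound 2, estimated as a 73-fold lower number from compound 2 to compound 3 (1.86 log units; beyond the scatter), with the two chlorine atoms adding uncertainty in either direction. For compound 3 the number in this assay is estimated at 200 nM, within a range from 30 nM to 2000 nM.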

Compound 3, half-maximal effective concentration: 1220 nM
For compound 3 the middle estimate is 6.1-fold (0.79 log units) below the measured one; the range from low to high includes it.
By their numbers in this assay, from the lowest: compound 1; then compound 3; then compound 2.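

In this assay, this position on the aromatic carbon of the five-membered ring with 4 nitrogen does not depend only on whether the entering ring is of carbon only: a 12-fold lower number from compound 2 to compound 3 (1.08 log units; beyond the scatter) shows that 3,4-dichlorophenyl recovers part of the loss seen with pyridin-2-yl, but not all of it. The other new comparison, a 13-fold higher number from compound 1 to compound 3 (1.10 log units; beyond the scatter), shows that the two chlorine atoms on the ring of carbon only go with a higher number than plain phenyl, so compound 3 lies between the other two, with each of its steps beyond the scatter. Nothing available accounts for either step, so the data record the order of these three compounds without explaining it.

The compounds shown leave open whether a single chlorine atom on the phenyl would give a number nearer that of compound 1 or that of compound 3, and whether methyl, methoxy or fluorine in place of the chlorine atoms would follow the same course. They also leave open whether pyridin-3-yl or pyridin-4-yl would carry the same large cost as pyridin-2-yl at this position.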